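Aryl swaps on the ring nitrogen of the shared core

The source may report more compounds than this note shows. Statements on the series, on what has been measured and on what is new or still open speak of the compounds shown alone.

Measured so far:
compound 1 `Cc1cccc(-n2nncc2CN2C(=O)C3(C(C#N)=C(N)Oc4c(N)cc5nc6ccccc6nc5c43)c3ccccc32)c1` — in an ADME assay on HUVEC cells (Homo sapiens) for antiproliferative activity, read by MTT assay, with a stated time of 48 h (on this read-out higher numbers stand for weaker inhibition and lower numbers for stronger inhibition), compound 1 gives > 50000 nM, a limit of the assay.
compound 2 `Cc1cc(C)cc(-n2nncc2CN2C(=O)C3(C(C#N)=C(N)Oc4c(N)cc5nc6ccccc6nc5c43)c3ccccc32)c1` — in this assay compound 2 gives > 50000 nM, a limit of the assay.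
compound 3 `N#CC1=C(N)Oc2c(N)cc3nc4ccccc4nc3c2C12C(=O)N(Cc1cnnn1-c1ccc(Cl)cc1[N+](=O)[O-])c1ccccc12` — in this assay compound 3 gives > 50000 nM, a limit of the assay.

Compound 3 thus sits at the limit, as do the two other values, all three at the limit of > 50000 nM in this assay, at which 3 of the 3 values shown sit. The steps a step that the two limits leave unreadable from compound 1 to compound 2, a step that the two limits leave unreadable from compound 1 to compound 3 and a step that the two limits leave unreadable from compound 2 to compound 3 therefore carry no readable size or direction.

Compound 4 `Cc1cc(C)c(-n2nncc2CN2C(=O)C3(C(C#N)=C(N)Oc4c(N)cc5nc6ccccc6nc5c43)c3ccccc32)c(C)c1` differs from compound 3 by 2,4,6-trimethylphenyl in place of 4-chloro-2-nitrophenyl on an aromatic nitrogen. The three measured steps bear on this change only in that every aryl group tried so far left the value at the limit; none of them gives a readable size. No step beyond the scatter is expected in this assay in either direction. The estimate for compound 4 is 50000 nM, with a range from 20000 nM to 100000 nM, which means an expected step of a number no higher from compound 3 to compound 4 (the limit leaves the size open), most likely reported again as a limit.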

Compound 4, half-maximal inhibitory concentration: > 50000 nM
Compound 4 ended at the assay's limit; the forecaster's own chance of this, stated with the estimate: 85%; the middle value lies on the limit itself.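

Compound 4 set against compound 1, compound 2 and compound 3 gives no readable step, as all four share one limit: the limit of > 50000 nM in this assay, at which 4 of the 4 values shown sit.

From the compounds shown here alone, still open: whether any aryl group at this place on the shared core gives a value short of the limit in this assay, and how the four compounds rank.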